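What a further methoxy may do to compound 3

This account rests on a few compounds, and the source may have more. Where it says the series, first, only, none or still open, it means among the compounds named here.

For the measured compounds named here, in a functional assay on HL-60 cells (Homo sapiens) for antiproliferative activity, read by MTT assay, with a stated time of 72 h (a lower number here means a stronger inhibitor, a higher number a weaker inhibitor), the compounds measured so far read as follows.

Compound 1 `COc1cc(C(=O)c2sc3ccccc3c2-c2ccc(F)cc2)cc(OC)c1OC` gives 3200 nM
Compound 2 `COc1cc(C(=O)c2sc3ccccc3c2-c2ccc(C)cc2)cc(OC)c1OC` gives 1400 nM
Compound 3 `COc1ccccc1-c1c(C(=O)c2cc(OC)c(OC)c(OC)c2)sc2ccccc12` gives 2900 nM

Going by the values given here, compound 3 cannot be told apart from the first compound on these numbers, with a 1.1-fold lower number from compound 1 to compound 3 (0.04 log units; within the scatter). It is weaker than the second, with a 2.1-fold higher number from compound 2 to compound 3 (0.32 log units; beyond the scatter).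

Compound 4 `COc1ccc(OC)c(-c2c(C(=O)c3cc(OC)c(OC)c(OC)c3)sc3ccccc23)c1` is still unmeasured. It turns 2-methoxyphenyl into 2,5-dimethoxyphenyl, with methoxy in place of hydrogen on an aromatic carbon, meta to a large group and para to a methoxy group (methoxy in place of hydrogen on an aromatic carbon).

Among the compounds with values here, no measured step makes this exact change, so the evidence is indirect. Swapping the group at this same spot has so far moved the number only a little, as a 2.3-fold lower number from compound 1 to compound 2 (0.36 log units; beyond the scatter) shows, and the two steps above are no larger. A step beyond the scatter is therefore not expected in this assay, and no direction can be favoured with confidence.

The expected change is a 1.2-fold lower number from compound 3 to compound 4 (0.06 log units; within the scatter).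

For compound 4 the estimate is 2500 nM, with an expected range from 1000 nM to 6000 nM.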

Compound 4, half-maximal inhibitory concentration: > 10000 nM
Compound 4 gave a limit, no number (the forecaster's own chance of this, stated with the estimate: 10%); middle value at least 4.0-fold (0.60 log units) from the limit.
By their numbers in this assay, from the lowest: compound 2; then compounds 3 and 1 (each within the scatter of the next). At a limit, above all of these: compound 4.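

In this assay compound 4 gives a limit and not a number: the limit of > 10000 nM in this assay, at which 1 of the 4 values shown sits. Even so, this position is not indifferent to change: turning 2-methoxyphenyl into 2,5-dimethoxyphenyl gives an at least 3.4-fold higher number from compound 3 to compound 4 (0.53 log units; beyond the scatter), a step beyond the scatter and larger than any step among the earlier compounds. The same group also sets compound 4 apart from the other two, with an at least 7.1-fold higher number from compound 2 to compound 4 (0.85 log units; beyond the scatter) and an at least 3.1-fold higher number from compound 1 to compound 4 (0.49 log units; beyond the scatter), so the small shifts seen earlier among the groups at this spot do not extend to 2,5-dimethoxyphenyl.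

The limit leaves the true size of these steps unknown, and a single compound cannot show whether the loss belongs to methoxy itself or to any group at this place. A hydroxy group or an amine on the same aromatic carbon would test that.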